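Indole amide series: carbonyl-linked substituent on the ring nitrogen

This account rests on a few compounds, and the source may have more. Where it says the series, first, only, none or still open, it means among the compounds named here.

Measured compounds:
compound 1 `CN1CCN(c2ccc(NC(=O)c3cc4cc(NC(=O)N(C)C)ccc4n3Cc3ccc(C(F)(F)F)cc3)cc2)CC1` — 1240 nM
compound 2 `CN1CCN(c2ccc(NC(=O)c3cc4cc(NS(C)(=O)=O)ccc4n3Cc3ccc(C(F)(F)F)cc3)cc2)CC1` — 4910 nM

In a functional assay on RAW264.7 cells (Mus musculus) for inhibition, read by ELISA, with stated times of 30 min and 24 h (a higher number here means a weaker inhibitor, a lower number a stronger inhibitor), compound 1 gives 1240 nM and compound 2 gives 4910 nM. Compound 2 thus holds the higher of the two numbers shown, the step being a 4.0-fold higher number from compound 1 to compound 2 (0.60 log units; beyond the scatter). For the measured compounds named here, the only change known so far exchanges dimethylcarbamoyl for methylsulfonyl on a nitrogen on an aromatic ring.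

Compound 3 `CN1CCN(c2ccc(NC(=O)c3cc4cc(N)ccc4n3Cc3ccc(C(F)(F)F)cc3)cc2)CC1` is not yet measured in this assay. Its difference from compound 2: hydrogen in place of methylsulfonyl on a nitrogen on an aromatic ring. Going by the values given here, no measured step removes a substituent from this nitrogen altogether, so the one known step bears on it only loosely: it shows that the group on this nitrogen shifts the number by a modest amount. For compound 3 the number is therefore expected to stay near compound 2 or move somewhat higher, with a broad range. The expected step is a 1.0-fold higher number from compound 2 to compound 3 (0.01 log units; within the scatter). Compound 3 is estimated at 5000 nM, between 1500 nM and 16000 nM.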

Compound 3, half-maximal inhibitory concentration: "not active" (no number reported)
For compound 3 the study gives words and no number; the estimate stays without a comparison.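

For the compounds shown here, compound 3 is reported only as "not active", with no number, so no step from compound 2 to compound 3 can be read. The compounds shown leave open how other groups on this nitrogen would read in this assay. Nothing given bears on a cause for this result.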